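From Compound 3 to Compound 4: A Side-Group Swap

The source may hold more compounds than are shown below. What is called first, only, known or untested is meant among the compounds shown, and "the series" means these compounds.

Of the compounds shown here, three have been tested in a functional assay on U2OS cells for antagonist activity at C-X-C chemokine receptor type 3 (Homo sapiens), read by beta-arrestin recruitment; a lower number here means a stronger inhibitor, a higher number a weaker inhibitor. Compound 1 `C[C@@H]1CN(c2sc(C3COC3)nc2-c2nc3ccccc3[nH]2)CCN1C(=O)Cn1cnc2cccnc21` gives 6220 nM, compound 2 `COc1ncc(-c2nc(C(F)(F)F)sc2N2CCN(C(=O)Cn3cnc4cccnc43)[C@H](C)C2)cn1` gives 177 nM, and compound 3 `CCOc1ncc(-c2nc(C(F)(F)F)sc2N2CCN(C(=O)Cn3cnc4ccccc43)[C@H](C)C2)cn1` gives 49 nM. Compound 3 therefore stands lowest of the three numbers, and since both of the gaps to its neighbours are beyond the scatter, it is the strongest inhibitor seen so far in this assay; compound 2 is the nearest to it, compound 1 the furthest away.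

Compound 4 `CCOc1ncc(-c2nc(C(F)(F)F)sc2N2CCN(C(=O)Cn3ccc(C(F)(F)F)n3)[C@H](C)C2)cn1` has not yet been measured. It keeps the whole of compound 3 apart from one change: 3-(trifluoromethyl)-1H-pyrazol-1-yl in place of 1H-benzimidazol-1-yl on a saturated chain carbon bound to a carbonyl carbon. For the measured compounds named here, no pair of measured compounds differs only in this way, so there is no directly comparable step to lean on. The group that leaves and the group that enters are both small five-membered-ring-containing pieces with the same count of heavy atoms and acceptors, but the shape and the fluorine content are quite different, so a modest shift toward a weaker number is expected rather than none at all. The step of a 2.7-fold higher number from compound 3 to compound 4 (0.42 log units; beyond the scatter) is the estimate this reasoning produces. Compound 4 is accordingly expected to give about 130 nM, in a range from 35 nM to 500 nM.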

Compound 4, half-maximal inhibitory concentration: 93 nM
For compound 4 the middle estimate is 1.4-fold (0.15 log units) above the measured one; measured number inside the range.
By their numbers in this assay, from the lowest: compounds 3, 4 and 2 (each within the scatter of the next, the first and the last beyond it); then compound 1.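

In this assay, for the compounds shown here, this is the first step that changes one place alone, so it is the first direct look at the group on the saturated chain carbon bound to a carbonyl carbon. Replacing 1H-benzimidazol-1-yl with 3-(trifluoromethyl)-1H-pyrazol-1-yl gives a 1.9-fold higher number from compound 3 to compound 4 (0.28 log units; within the scatter) and so, on this shared core, the two groups cannot be told apart in this assay, even though the entering group has lost the six-membered aromatic ring of carbon only and gained three fluorine atoms. No measurement shown here explains why these two different groups give readings within the scatter of each other.

This single pair cannot show which part of the entering group matters, and a plain 1H-pyrazol-1-yl or a pyrazole carrying a methyl group in place of the trifluoromethyl would separate the role of the ring from that of the fluorine atoms. Going by these compounds alone, it also remains open whether the same swap would be tolerated on a different core, such as the one in compound 1, where the rest of the molecule differs in more than one place.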